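The source may hold more compounds than are shown below. What is called first, only, known or untested is meant among the compounds shown, and "the series" means these compounds.

In a functional assay on PANC-1 cells (Homo sapiens) for cytotoxicity, read by MTT assay, with a stated time of 72 h (a lower number here means a stronger inhibitor, a higher number a weaker inhibitor), three compounds have been measured:

compound 1 `O=C1C(Nc2ccc(OC(F)(F)F)cc2)=CC(=O)c2ncncc21`: 900 nM
compound 2 `Nc1ccc(-c2ccc(NC3=CC(=O)c4ncncc4C3=O)cc2)cc1`: 3700 nM
compound 3 `CCc1ccc(-c2ccc(NC3=CC(=O)c4ncncc4C3=O)cc2)cc1`: 1200 nM

Compound 3 holds the second highest number of the three. Its gap to compound 1 is small, a 1.3-fold higher number from compound 1 to compound 3 (0.12 log units; within the scatter), whereas compound 2 stands clearly apart, a 3.1-fold lower number from compound 2 to compound 3 (0.49 log units; beyond the scatter). Compound 4 `NS(=O)(=O)c1ccc(NC2=CC(=O)c3ncncc3C2=O)cc1` carries a single change: sulfamoyl in place of 4-ethylphenyl on an aromatic carbon. Going by the values given here, no measured step introduces a sulfamoyl group, so the guidance is indirect. The step of a 1.3-fold higher number from compound 1 to compound 3 (0.12 log units; within the scatter) shows that swapping the group at this position can leave the number nearly unchanged, while a 3.1-fold lower number from compound 2 to compound 3 (0.49 log units; beyond the scatter) shows a modest shift when ethyl and amino are exchanged. A modest rise is therefore expected, a 2.1-fold higher number from compound 3 to compound 4 (0.32 log units; beyond the scatter). Compound 4 is estimated at 2500 nM, in a range from 900 nM to 7000 nM.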

Compound 4, half-maximal inhibitory concentration: > 10000 nM
Compound 4: a limit, no number; the forecaster's own chance of this, stated with the estimate: 10%; middle value at least 4.0-fold (0.60 log units) away from the limit.
By their numbers in this assay, from the lowest: compounds 1 and 3 (each within the scatter of the next); then compound 2. At a limit, above all of these: compound 4.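

Compound 4 gives only a limit, not a number: the limit of > 10000 nM in this assay, at which 1 of the 4 values shown sits. Going by these compounds alone, this position had so far carried trifluoromethoxy, 4-aminophenyl and 4-ethylphenyl with measurable numbers, whereas sulfamoyl there gives an at least 8.3-fold higher number from compound 3 to compound 4 (0.92 log units; beyond the scatter), an at least 2.7-fold higher number from compound 2 to compound 4 (0.43 log units; beyond the scatter) and an at least 11-fold higher number from compound 1 to compound 4 (1.04 log units; beyond the scatter). So the position does not accept every group equally, and this single change weakens the compounds more than any earlier step did. From the compounds shown here alone, whether a carboxylic acid or a simple amine in the same place would also reach such a limit remains open.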